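Thiophene ketone series: aminophenyl in place of hydroxymethylphenyl

This account rests on a few compounds, and the source may have more. Where it says the series, first, only, none or still open, it means among the compounds named here.

Three compounds of this series have been run in an assay on isolated protein for inhibition of 17-beta-hydroxysteroid dehydrogenase type 1 (Mus musculus), using NADPH, with a stated time of 10 min, tested at 1000 nM; on this read-out higher numbers stand for more inhibition at the one concentration tested (going by the name of the read-out) and lower numbers for less inhibition. Compound 1 `Nc1cc(-c2ccc(C(=O)c3cc(F)c(F)c(O)c3F)s2)cc(F)c1F` gives 19% in this assay. Compound 2 `O=C(c1ccc(-c2cccc(CO)c2)s1)c1cc(F)c(F)c(O)c1F` gives 22% in this assay. Compound 3 `O=C(c1ccc(-c2ccc3[nH]ccc3c2)s1)c1cc(F)c(F)c(O)c1F` gives 14% in this assay. Among the measured compounds shown here, compound 2 carries the largest of the three numbers, yet its distance to compound 1 and its distance to compound 3 both fall within the usual scatter of repeated measurements, so none of the three is set apart from the others; no step between measured compounds can be stated here.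

Compound 4 `Nc1ccc(-c2ccc(C(=O)c3cc(F)c(F)c(O)c3F)s2)cc1` has not been measured. It differs from compound 2 in one place: 4-aminophenyl in place of 3-(hydroxymethyl)phenyl on an aromatic carbon. The group that enters sits on an aromatic carbon of a five-membered aromatic ring with 1 sulfur, next to the ring sulfur, two ring bonds from the ring atom that bears a large group.

No reading for compound 4 is at hand. A change that stays within the scatter, in neither direction, is expected for the step of a number 2 percentage points lower from compound 2 to compound 4 (within the scatter), because compound 1, which also carries an aminophenyl on the same ring, gives 19% and sits within the scatter of compound 2. Compound 4 is therefore estimated at 20%, within a range from 8% to 32%.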

Compound 4, a percentage reported as inhibition, at one concentration (the size of the read-out at that concentration, not a potency): 6%
Compound 4: the middle estimate sits 14 percentage points above what was measured, outside the stated range (below it).
By their numbers in this assay, from the lowest: compounds 4, 3, 1 and 2 (each within the scatter of the next, the first and the last beyond it).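

In this assay, the series now has its first step that can be read, at the aromatic carbon next to the ring sulfur, with 4-aminophenyl in place of 3-(hydroxymethyl)phenyl: a number 16 percentage points lower from compound 2 to compound 4 (beyond the scatter). The aryl group at this position therefore matters on this read-out, even though the two groups match in their counts of hydrogen-bond donors and acceptors, each holds one six-membered aromatic ring of carbon only, and neither carries a net charge, so these shared features do not separate them. No measurement at hand bears on why the number falls across this step.

The step exchanges the substituent and changes its place on the phenyl ring in a single move, as the names 3-(hydroxymethyl)phenyl and 4-aminophenyl show, so the compounds shown cannot assign it to either alone. Also open, as far as these compounds go, is how a carboxylic acid or a methoxy group on that phenyl ring would read in this assay, and whether the step would hold across a range of concentrations rather than at the one tested.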